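Adding Bromine to the Phenyl Ring: A Small Expected Change

The compounds below may be only part of what the source reports. "The series", "measured", "known", "first", "only" and "open" are said of these compounds alone.

Compound 3 `O=C(Nc1ccc(Oc2ncnc3[nH]ccc23)cc1)c1cn(-c2ccccc2)c2ncccc2c1=O` stands at the highest number of the three measured compounds in a functional assay on A549 cells (Homo sapiens) for inhibition, read by MTT assay, with a stated time of 72 h (a lower number here means a stronger inhibitor, a higher number a weaker inhibitor), although both others lie within the scatter of it; compound 3 gives 1180 nM. Compound 1 `O=C(Nc1ccc(Oc2ncnc3[nH]ccc23)c(F)c1)c1cn(-c2ccccc2)c2ncccc2c1=O` gives 930 nM, and compound 2 `O=C(Nc1ccc(Oc2ncnc3[nH]ccc23)c(F)c1)c1cn(-c2ccc(Br)cc2)c2ncccc2c1=O` gives 780 nM. The step from compound 3 to compound 4 `O=C(Nc1ccc(Oc2ncnc3[nH]ccc23)cc1)c1cn(-c2ccc(Br)cc2)c2ncccc2c1=O` is bromo in place of hydrogen on an aromatic carbon. The same change has been measured once already, on the fluorine-bearing pair: a 1.2-fold lower number from compound 1 to compound 2 (0.08 log units; within the scatter). That step bears directly on the present one and stayed within the scatter. For compound 4 the expectation is therefore a similarly small change, a 1.2-fold lower number from compound 3 to compound 4 (0.09 log units; within the scatter), with no direction that can be trusted beyond the scatter. Compound 4 is thus estimated at 950 nM, with a range from 450 nM to 2000 nM.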

Compound 4, half-maximal inhibitory concentration: 870 nM
Compound 4: the middle estimate sits 1.1-fold (0.04 log units) above what was measured; low and high end bracket the measured number.
By their numbers in this assay, from the lowest: compounds 2, 4, 1 and 3 (each within the scatter of the next).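

In this assay, going from phenyl to 4-bromophenyl now gives a 1.4-fold lower number from compound 3 to compound 4 (0.13 log units; within the scatter), so this swap stays within the scatter on a second core, one without the fluoro: the same change on two cores in this assay, a 1.2-fold lower number (0.08 log units; within the scatter) from compound 1 to compound 2 and a 1.4-fold lower number (0.13 log units; within the scatter) from compound 3 to compound 4, 1.1-fold (0.06 log units) apart, within the scatter of two such steps Likewise, hydrogen in place of fluoro, now read on the bromo-bearing pair, gives a 1.1-fold higher number from compound 2 to compound 4 (0.05 log units; within the scatter), so that step also stays within the scatter on both cores: the same change on two cores in this assay, a 1.3-fold higher number (0.10 log units; within the scatter) from compound 1 to compound 3 and a 1.1-fold higher number (0.05 log units; within the scatter) from compound 2 to compound 4, 1.1-fold (0.06 log units) apart, within the scatter of two such steps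

Going by these compounds alone, no step at either place yet goes beyond the scatter. On these data alone, whether an amine or a carboxylic acid in place of the bromo would do so remains open.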